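The compounds below may be only part of what the source reports. "The series", "measured", "known", "first", "only" and "open" are said of these compounds alone.

Compound 1, `FC(F)(F)c1ccc(CSc2nc(N3CCCCC3)c3ccccc3n2)cc1`, is the starting point of this step. In a functional assay on MDA-MB-231 cells (Homo sapiens) for cytotoxicity, read by MTT assay, with a stated time of 72 h (a lower number here means a stronger inhibitor, a higher number a weaker inhibitor), compound 1 gives 28400 nM, the higher of the two numbers in this small set. Its nearest neighbour is compound 2, `FC(F)(F)c1ccc(CSc2nc(Nc3cccc(Br)c3)c3ccccc3n2)cc1`, which in this assay gives 22100 nM; the change between them, a 1.3-fold lower number from compound 1 to compound 2 (0.11 log units; within the scatter), is within the scatter. Compound 3, `Cc1ccc(Nc2nc(SCc3ccc(C(F)(F)F)cc3)nc3ccccc23)cc1`, returns only a limit in this assay, > 50000 nM, which is the limit at which one of the three values sits, (the limit of > 50000 nM in this assay, at which 1 of the 3 values shown sits). From compound 1 the step to compound 3 was an at least 1.7-fold higher number from compound 1 to compound 3 (0.24 log units; that floor lies within the scatter), and between the two arylamines the step was an at least 2.2-fold higher number from compound 2 to compound 3 (0.35 log units; beyond the scatter).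

Compound 4, `COc1cc(Nc2nc(SCc3ccc(C(F)(F)F)cc3)nc3ccccc23)cc(OC)c1`, has not yet been measured. It differs from compound 1 in one place: (3,5-dimethoxyphenyl)amino in place of piperidin-1-yl on an aromatic carbon. The two measured steps that bear on this change both replace piperidin-1-yl with an arylamino group: one gave a change within the scatter, the other a move to weaker inhibition that ends at a limit. Compound 4 is therefore expected to sit close to compound 1 or somewhat weaker, with the step of a 1.6-fold higher number from compound 1 to compound 4 (0.20 log units; within the scatter) estimated as small and, if anything, toward a higher number. The estimate for compound 4 in this assay is 45000 nM, with a range from 18000 nM to 120000 nM.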

Compound 4, half-maximal inhibitory concentration: 16100 nM
Beside the measured number, compound 4's estimate is 2.8-fold (0.45 log units) above it; the measured number lies below the stated range.
By their numbers in this assay, from the lowest: compounds 4, 2 and 1 (each within the scatter of the next). At a limit, above all of these: compound 3.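

At this aromatic carbon of the shared core, a third arylamino group shows that replacing piperidin-1-yl need not cost anything in this assay: the step is a 1.8-fold lower number from compound 1 to compound 4 (0.25 log units; within the scatter), and the step between the two arylamines that carry measured numbers is a 1.4-fold lower number from compound 2 to compound 4 (0.14 log units; within the scatter), so these three values form one group with no order among them. The aryl ring decides the outcome, not the arylamino link as such, and the 4-methylphenyl case is the one that goes against the group, with the step of an at least 3.1-fold lower number from compound 3 to compound 4 (0.49 log units; beyond the scatter). Compound 3 holds no number here, only a limit: the limit of > 50000 nM in this assay, at which 1 of the 4 values shown sits.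

The compounds shown do not separate the kind of a substituent on the aryl ring from its place on that ring, and what a single methoxy group or an unsubstituted phenyl ring would give remains open. Also open, as far as these compounds go, is whether a morpholine ring or an open-chain dialkylamine at this carbon would fall in the same group, and whether any of these values would move with a change to the trifluoromethyl-bearing benzyl group.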